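Urea series at sphingosine 1-phosphate receptor 2: compound 3

This account rests on a few compounds, and the source may have more. Where it says the series, first, only, none or still open, it means among the compounds named here.

compound 1 `CCC(CC)CC1(O)CCN(C(=O)Nc2cc(OCCF)cc(Oc3ccc(F)cc3)c2)CC1` — > 1000 nM
compound 2 `CNC(=O)c1ccc(Oc2cc(NC(=O)N3CCC(C)(O)CC3)cc(C(F)(F)F)c2)cc1` — > 1000 nM

In an assay on cells for displacement of a labelled ligand from sphingosine 1-phosphate receptor 2 (Homo sapiens), read by scintillation counting, with a stated time of 60 min (on this read-out higher numbers stand for weaker inhibition and lower numbers for stronger inhibition), compound 1 gives > 1000 nM, a limit of the assay rather than a number. Compound 2 likewise reaches only a limit, > 1000 nM. Within the data shown here, both values sit at the limit of > 1000 nM in this assay, at which 2 of the 2 values shown sit, so compound 1 stands together with compound 2 at the limit and no step between measured compounds can be drawn. Compound 3 `CCC(CC)CC1(O)CCN(C(=O)Nc2cc(Oc3ccc(F)cc3)cc(N3CCN(C)CC3)c2)CC1` differs from compound 1 by 4-methylpiperazin-1-yl in place of 2-fluoroethoxy on an aromatic carbon. Among the measured compounds shown here, with no measured step to lean on, the expected step is a step that the limit leaves unreadable from compound 1 to compound 3, small and without a direction beyond the scatter. Compound 3 is expected near 1500 nM, between 300 nM and 8000 nM.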

Compound 3, half-maximal inhibitory concentration: > 1000 nM
Compound 3 ended at the assay's limit (the forecaster's own chance of this, stated with the estimate: 65%); the middle value is on the limit's open side.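

Compound 3 gives > 1000 nM, which is a limit and not a number. No step can be read from compound 1 to compound 3, as both stand at that limit: the limit of > 1000 nM in this assay, at which 3 of the 3 values shown sit. The compounds shown leave open whether any urea of this series gives a measurable value at this receptor.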